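Half-life after intravenous dosing: the two stereoisomers around compound 1

The source may hold more compounds than are shown below. What is called first, only, known or untested is meant among the compounds shown, and "the series" means these compounds.

Measured so far:
compound 1 `COC(=O)N[C@H](C(=O)N1CCC[C@H]1C(=O)Nc1ccc([C@@H]2CC[C@@H](c3ccc(NC(=O)[C@@H]4CCCN4C(=O)[C@@H](NC(=O)OC)[C@H]4CCOC4)cc3)N2c2ccc(F)cc2)cc1)[C@H]1CCOC1` — 0.9 h
compound 2 `COC(=O)N[C@H](C(=O)N1CCC[C@H]1C(=O)Nc1ccc([C@H]2CC[C@H](c3ccc(NC(=O)[C@@H]4CCCN4C(=O)[C@@H](NC(=O)OC)C(C)C)cc3)N2c2ccc(F)cc2)cc1)C(C)C` — 3.3 h

In an ADME assay on the whole organism for metabolic stability, with Rattus norvegicus as the target, at a dose of 3 mg/kg by the intravenous route (a lower number here means that the compound disappears faster, a higher number that the compound lasts longer), compound 1 gives 0.9 h, the lowest of the two numbers in hand. Compound 2 gives 3.3 h in this assay; the gap between the two lies beyond the scatter, but compound 2 differs from compound 1 in more than one place, so no single step can be read from that pair.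

Compound 3 `COC(=O)N[C@H](C(=O)N1CCC[C@H]1C(=O)Nc1ccc([C@H]2CC[C@H](c3ccc(NC(=O)[C@@H]4CCCN4C(=O)[C@@H](NC(=O)OC)[C@H]4CCOC4)cc3)N2c2ccc(F)cc2)cc1)[C@H]1CCOC1` is not yet measured. Relative to compound 1 the change is the two compounds have the same atoms and bonds and differ only in configuration as drawn: 2 of 8 stereo elements differ; a stereocentre at a saturated ring carbon is drawn S in compound 1 and R in compound 3; a stereocentre at a saturated ring carbon is drawn S in compound 1 and R in compound 3. Going by the values given here, no measured pair shows what this inversion alone does to half-life. The only pointer is that the ring configuration drawn for compound 3 is shared with compound 2, and in this assay compound 2 stands higher with 3.3 h. That pointer is weak: other parts of compound 2 also differ.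

For compound 3 a moderate rise is expected, with the step from compound 1 estimated as a 1.7-fold higher number from compound 1 to compound 3 (0.22 log units; within the scatter), though a result within the scatter of compound 1 cannot be excluded. The half-life of compound 3 is estimated at 1.5 h, with a range from 0.7 h to 3.5 h.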

Compound 3, half-life: 0.8 h
Compound 3: middle estimate off by 1.9-fold (0.27 log units), on the high side, within the range that was stated.
By their numbers in this assay, from the lowest: compounds 3 and 1 (each within the scatter of the next); then compound 2.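

In this assay, going by these compounds alone, the step of a 1.1-fold lower number from compound 1 to compound 3 (0.05 log units; within the scatter) is the first reading of a single change, the inversion of both stereocentres at saturated ring carbons, and it lies within the scatter. On the background of compound 1, inverting these two stereocentres together thus gives no readable change in half-life, and the two configurations count as equal in this measurement. The comparison is a clean one, with no change of atoms or bonds to separate from the inversion: the fact that compounds 1 and 3 differ only in the configuration as drawn.

Within the data shown here, the pair leaves open what each stereocentre does when inverted alone, and whether the inversion stays without a readable result when the end groups differ; compound 2 differs from both in more than its configuration, so its 3.3 h gives no step for this question. Also open is whether a carboxylic acid or an amine on the shared core would shift the numbers in this assay, since the compounds shown carry neither group.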